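A few compounds are considered here, and "the series" means these few. Any claim that something is new, unique, unknown or untested is made for them only; others in the source may bear on it.

Within the shared core the ester acyl group is what changes. In a functional assay on A549 cells (Homo sapiens) for cytotoxicity, read by MTT assay, with a stated time of 48 h (on this read-out lower numbers stand for stronger inhibition and higher numbers for weaker inhibition), compound 1 `C=C1C(=O)O[C@H]2CC3=C[C@H](C/C(C)=C/[C@@H](OC(=O)c4ccc(-c5ccccc5)cc4)[C@H]12)OC3=O` gives 4600 nM, and compound 2 `C=C1C(=O)O[C@H]2CC3=C[C@H](C/C(C)=C/[C@@H](OC(=O)/C=C/c4cccc(OC)c4)[C@H]12)OC3=O` gives 6200 nM in this assay. Compound 3 `C=C1C(=O)O[C@H]2CC3=C[C@H](C/C(C)=C/[C@@H](OC(=O)CCl)[C@H]12)OC3=O`, with a chloromethyl on the carbonyl carbon, reaches only a limit of this assay, > 10000 nM, and so stands at the weak end of the shown numbers, as the limit of > 10000 nM in this assay, at which 1 of the 3 values shown sits, records. Among the compounds with values here, the one measured step that touches compound 3 is an at least 1.6-fold higher number from compound 2 to compound 3 (0.20 log units; that floor lies within the scatter). Compound 4 `C=C1C(=O)O[C@H]2CC3=C[C@H](C/C(C)=C/[C@@H](OC(=O)c4ccncc4)[C@H]12)OC3=O` differs from compound 3 as pyridin-4-yl in place of chloromethyl on a carbonyl carbon, bringing back an aromatic acyl group. Because compound 1 gives 4600 nM with such a group, compound 4 is expected to take a step of an at least 1.6-fold lower number from compound 3 to compound 4 (0.22 log units; that floor lies within the scatter) towards lower numbers. Compound 4 is estimated at 6000 nM, with a range from 2500 nM to 15000 nM.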

Compound 4, half-maximal inhibitory concentration: > 10000 nM
Compound 4 was reported as a limit; the forecaster's own chance of this, stated with the estimate: 30%; middle value at least 1.6-fold (0.22 log units) from the limit.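

In this assay compound 4, with pyridin-4-yl on the carbonyl carbon, gives > 10000 nM, which is a limit of the assay. Within the data shown here, an aromatic ring on this carbonyl carbon is therefore not enough on its own to give a measurable number, though the one readable step is small: an at least 1.6-fold higher number from compound 2 to compound 4 (0.20 log units; that floor lies within the scatter). The step between the two limits cannot be read, and the weak end now holds both chloromethyl and pyridin-4-yl: the limit of > 10000 nM in this assay, at which 2 of the 4 values shown sit.

Going by these compounds, how far compound 3 and compound 4 lie beyond the limit stays open. So does whether phenyl in place of pyridin-4-yl, or a longer chain ending in an amine, would return a measurable number.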